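The source may hold more compounds than are shown below. What is called first, only, known or untested is meant among the compounds shown, and "the series" means these compounds.

Working notes on the series. Going by the values given here, compound 1 `CCOC(=O)CSc1nncc2cnc(C)n12` is the only member with a number in a functional assay for inhibition, with Homo sapiens as the target; on this read-out higher numbers stand for weaker inhibition and lower numbers for stronger inhibition: compound 1 gives 52000 nM. Compound 2 `CCOC(=O)CSc1nncc2c(C)nc(C)n12` returns only a limit of the assay, > 48000 nM. Compound 3 `CSc1nncc2cnc(C)n12` likewise returns a limit of the assay, > 48000 nM. The two measured steps from compound 1, a step that the limit leaves unreadable from compound 1 to compound 2 and a step that the limit leaves unreadable from compound 1 to compound 3, are unreadable because of the limit of > 48000 nM in this assay, at which 2 of the 3 values shown sit. Compound 4 `CCOC(=O)CSc1nncc2cncn12` differs from compound 1 by hydrogen in place of methyl on an aromatic carbon. Neither measured step gives a readable size for such a change in this assay, so no direction beyond the scatter can be derived, and compound 1 itself sits at weak inhibition. Compound 4 is estimated at 60000 nM, within a range from 25000 nM to 150000 nM. For compound 4 the expected step is a 1.2-fold higher number from compound 1 to compound 4 (0.06 log units; within the scatter).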

Compound 4, half-maximal inhibitory concentration: > 48000 nM
Compound 4: only a limit was reported; the forecaster's own chance of this, stated with the estimate: 60%; the middle value lies beyond the limit too.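

Going by these compounds alone, no step from compound 1 to compound 4 can be read, because compound 4 returns only a limit of the assay: the limit of > 48000 nM in this assay, at which 3 of the 4 values shown sit. The compounds shown leave open whether any of these changes strengthens or weakens inhibition relative to compound 1.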